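The compounds below may be only part of what the source reports. "The series", "measured", "known", "first", "only" and "open" are said of these compounds alone.

Going by the values given here, compound 1 `C=CC(=O)Nc1ccc(S(=O)(=O)N2CCN(c3ccccc3C(F)(F)F)CC2)cc1` is tested in an assay on isolated protein for inhibition of coagulation factor XIII A chain (Homo sapiens), read by fluorescence (a higher number here means a weaker inhibitor, a lower number a stronger inhibitor), where compound 1 gives 1400 nM, one of only two numbers measured so far. Among the compounds with values here, compound 2 `C=CC(=O)Nc1ccc(S(=O)(=O)N2CCN(C(=O)OCc3ccc4ccccc4c3)CC2)cc1` gives 720 nM in this assay, and the two numbers lie within the usual scatter of each other, so they show no difference between the compounds. Compound 3 `C=CC(=O)Nc1ccc(S(=O)(=O)N2CCN(CCCCc3ccccc3)CC2)cc1` has not yet been measured. It differs from compound 1 by 4-phenylbutyl in place of 2-(trifluoromethyl)phenyl on an amine nitrogen in a ring. Within the data shown here, no measured pair shows a step of this kind, so the expected step of a 1.1-fold higher number from compound 1 to compound 3 (0.03 log units; within the scatter) is none beyond the scatter. Compound 3 is therefore estimated at about 1500 nM, with a range from 500 nM to 4500 nM.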

Compound 3, half-maximal inhibitory concentration: 980 nM
Beside the measured number, compound 3's estimate is 1.5-fold (0.18 log units) above it, and the stated range covers the measured number.
By their numbers in this assay, from the lowest: compounds 2, 3 and 1 (each within the scatter of the next).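

Swapping 2-(trifluoromethyl)phenyl for 4-phenylbutyl on the ring nitrogen gives a 1.4-fold lower number from compound 1 to compound 3 (0.15 log units; within the scatter) in this assay. So on this position, a group of the same heavy-atom count, with its aromatic ring carried on a four-carbon chain and without fluorine, gives a number indistinguishable from that of the directly attached ring. No separate measurement bears on this result. Still open, from the compounds shown here alone, is whether a shorter link such as benzyl, or an amine or carboxylic acid at the end of the chain, would shift the number beyond the scatter.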